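This account rests on a few compounds, and the source may have more. Where it says the series, first, only, none or still open, it means among the compounds named here.

For the measured compounds named here, in a functional assay on GOTO cells (Homo sapiens) for cytotoxicity, read by MTT assay, with a stated time of 3 days (a higher number here means a weaker inhibitor, a lower number a stronger inhibitor), compound 1 `N#Cc1c(O)nc(SCc2nc3ccccc3[nH]2)nc1-c1ccccc1` gives 7.81 nM, while compound 2 `N#Cc1c(NN)nc(SCc2nc3ccccc3[nH]2)nc1-c1ccccc1` gives 2.68 nM, the lower of the two numbers so far. Compound 3 `N#Cc1c(Nc2ccccc2)nc(SCc2nc3ccccc3[nH]2)nc1-c1ccccc1` has phenyl in place of amino on a nitrogen on an aromatic ring. Going by the values given here, the only measured guide is a 2.9-fold lower number from compound 1 to compound 2 (0.46 log units; beyond the scatter), a modest step beyond the scatter, made by putting aminoamino in place of hydroxy. That is a different exchange, so no step beyond the scatter is expected in this assay, with a slightly higher number perhaps. The estimated change is a 1.5-fold higher number from compound 2 to compound 3 (0.17 log units; within the scatter). Compound 3 is expected at 4 nM, within a range of 1.3 nM to 12 nM.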

Compound 3, half-maximal inhibitory concentration: 6.41 nM
Compound 3: middle estimate off by 1.6-fold (0.20 log units), on the low side; low and high end bracket the measured number.
By their numbers in this assay, from the lowest: compound 2; then compounds 3 and 1 (each within the scatter of the next).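

With phenyl in place of amino on a nitrogen on an aromatic ring, this assay shows a 2.4-fold higher number from compound 2 to compound 3 (0.38 log units; beyond the scatter), so the advantage of aminoamino over hydroxy does not extend to anilino. Anilino in place of hydroxy on the same aromatic carbon gives a 1.2-fold lower number from compound 1 to compound 3 (0.09 log units; within the scatter), so these two groups cannot be told apart here, despite the added six-membered aromatic ring. No measurement shown explains either step.

Still open, going by these compounds, is whether the end amino of aminoamino matters, or whether any small nitrogen group would serve equally. A plain amine or a methylamino group on this aromatic carbon would test that.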